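A few compounds are considered here, and "the series" means these few. Any claim that something is new, unique, unknown or untested is made for them only; others in the source may bear on it.

Measured so far:
- compound 1 `NC1=NC2(CCSCC2)N(OCCCOc2ccc(Cl)c(Cl)c2)C(N)=N1`: 70 nM
- compound 2 `CC(C)(C)c1ccc(OCCCON2C(N)=NC(N)=NC23CCSCC3)cc1`: 70 nM
- compound 3 `NC1=NC2(CCOCC2)N(OCCCOc2cccc(Cl)c2Cl)C(N)=N1`: 330 nM

All three values come from a functional assay on HepG2 cells (Homo sapiens) for antiproliferative activity, read by MTT assay, with a stated time of 72 h; a lower number here means a stronger inhibitor, a higher number a weaker inhibitor. Compound 3 at 330 nM has the highest of the three numbers, and its distance to each of the other two lies beyond the scatter. Compound 1 and compound 2 show the same number.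

Next in the series is compound 4 `NC1=NC2(CCOCC2)N(OCCCOc2ccccc2Br)C(N)=N1`, not yet measured. It keeps the core of compound 3 and carries 2-bromophenyl in place of 2,3-dichlorophenyl on an oxygen on a saturated carbon. For the measured compounds named here, no measured pair isolates this exchange, so the expectation stays close to compound 3 at 330 nM and the range is kept wide. No step beyond the scatter is expected in this assay, with a slight lean towards a higher number. The expected change is a 1.4-fold higher number from compound 3 to compound 4 (0.13 log units; within the scatter), which remains an estimate until the measurement is in. For compound 4 the estimated value is 450 nM, with an expected range of 150 nM to 1300 nM.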

Compound 4, half-maximal inhibitory concentration: 860 nM
Compound 4: middle estimate off by 1.9-fold (0.28 log units), on the low side; the measured number falls inside the stated range.
By their numbers in this assay, from the lowest: compounds 1 and 2 (each within the scatter of the next); then compound 3; then compound 4.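

In this assay, for the compounds shown here, 2-bromophenyl in place of 2,3-dichlorophenyl on an oxygen on a saturated carbon, with the core unchanged, gives a 2.6-fold higher number from compound 3 to compound 4 (0.42 log units; beyond the scatter), the first single-place step, showing that the activity responds to a change at this position. The exchange replaces two chlorine atoms with one bromine, so the kind of halogen and the number of halogens change together. No measurement at hand accounts for the step.

On these data alone, it remains open whether 2-chlorophenyl would separate these two changes, and whether an amine or a carboxylic acid on the phenyl ring would be tolerated at this position. As far as these compounds go, it is also open whether the same exchange would give a similar step on the core of compound 1.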